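Removing one methyl from compound 2

The source may report more compounds than this note shows. Statements on the series, on what has been measured and on what is new or still open speak of the compounds shown alone.

Measured in a functional assay on cells (Cancer cell lines, Homo sapiens) for inhibition; on this read-out higher numbers stand for weaker inhibition of growth and lower numbers for stronger inhibition of growth:
- compound 1 `Cc1cc(-c2nc3sc(C)cn3c2/C=N/NC(=N)N)c(C)s1` gives 4470 nM
- compound 2 `Cc1cn2c(/C=N/NC(=N)N)c(-c3ccsc3)nc2s1` gives 7760 nM
- compound 3 `N=C(N)N/N=C/c1c(-c2cc(Cl)sc2Cl)nc2n1CCS2` gives 12300 nM

The number for compound 2 cannot be told apart from those of its two neighbours on the scale, compound 1 and compound 3, as both gaps lie within the usual scatter. The next compound to be measured is compound 4 `N=C(N)N/N=C/c1c(-c2ccsc2)nc2sccn12`. It differs from compound 2 by hydrogen in place of methyl on an aromatic carbon, next to the ring sulfur.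

For the measured compounds named here, only one measured step bears on this change, and it sits on a different ring. Going to thiophen-3-yl in place of 2,5-dimethylthiophen-3-yl gave a 1.7-fold higher number from compound 1 to compound 2 (0.24 log units; within the scatter). Losing methyl groups there made no change beyond the scatter, though a single step is thin evidence. No clear change is expected in this assay, at most a slight drift towards a higher number. The expected step is a 1.2-fold higher number from compound 2 to compound 4 (0.06 log units; within the scatter). Compound 4 is estimated at 9000 nM, with an expected range of 4000 nM to 20000 nM.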

Compound 4, concentration for 50% growth inhibition: 17400 nM
Estimate against measurement, compound 4: 1.9-fold (0.29 log units) below; the range from low to high includes it.
By their numbers in this assay, from the lowest: compounds 1, 2, 3 and 4 (each within the scatter of the next, the first and the last beyond it).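

In this assay, the change from methyl to hydrogen on this aromatic carbon, next to the ring sulfur, gives a 2.2-fold higher number from compound 2 to compound 4 (0.35 log units; beyond the scatter). For the compounds shown here, this is the first single change to pass the scatter, since the earlier change on the thiophene ring, a 1.7-fold higher number from compound 1 to compound 2 (0.24 log units; within the scatter), did not. The methyl at this position therefore goes with stronger inhibition of growth, although the step is modest and rests on one pair of compounds, and no available measurement explains it.

The compounds shown leave open how an ethyl group or a chlorine atom on this same carbon would compare with methyl and hydrogen. Going by these compounds, it is also open whether removing this methyl gives a similar step when the other ring is 2,5-dimethylthiophen-3-yl, as in compound 1.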